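The source may report more compounds than this note shows. Statements on the series, on what has been measured and on what is new or still open speak of the compounds shown alone.

The three compounds with numbers so far:

Compound 1, `CC(C)C[C@H](N)c1cc(C(F)(F)F)ccc1N1CCN(C(=O)CCc2csc3ccccc23)CC1`, gives 2300 nM in an assay on HEK293 cells for displacement of a labelled ligand from Melanocortin receptor 4 (Homo sapiens); a higher number here means a weaker inhibitor, a lower number a stronger inhibitor.
Compound 2, `Cc1[nH]c2ccccc2c1CCC(=O)N1CCN(c2ccc(C(F)(F)F)cc2[C@@H](N)CC(C)C)CC1`, gives 1600 nM in this assay.
Compound 3, `CCC(C)CN[C@H](c1cc(C(F)(F)F)ccc1N1CCN(C(=O)CCc2ccc(Cl)cc2Cl)CC1)C(C)CC`, gives 2800 nM in this assay.

Compound 3 carries the highest of the three numbers, yet its gap to compound 1 and its gap to compound 2 both sit within the usual scatter, so the three cannot be ranked. Within the data shown here, the one measured step, a 1.4-fold lower number from compound 1 to compound 2 (0.16 log units; within the scatter), swaps the aromatic group at the far end of the amide chain and is also within the scatter.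

Compound 4, `COCCN[C@@H](CC(C)C)c1cc(C(F)(F)F)ccc1N1CCN(C(=O)CCc2ccc(Cl)cc2Cl)CC1`, differs from compound 3 at the other end of the molecule: 1-((2-methoxyethyl)amino)-3-methylbutyl in place of 2-methyl-1-((2-methylbutyl)amino)butyl on an aromatic carbon. The substituent that leaves has no ring and one hydrogen-bond acceptor; the one that enters has no ring and two hydrogen-bond acceptors, and is one heavy atom smaller. Among the measured compounds shown here, no measured step touches this part of the shared core, so nothing here tells how large a move to expect in this assay, in either direction. The number for compound 4 is therefore expected to stay close to that of compound 3, with a wide range: 1800 nM, between 400 nM and 8000 nM. The expected step is a 1.6-fold lower number from compound 3 to compound 4 (0.19 log units; within the scatter).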

Compound 4, inhibition constant: 620 nM
Compound 4: middle estimate off by 2.9-fold (0.46 log units), on the high side; the measured number falls inside the stated range.
By their numbers in this assay, from the lowest: compound 4; then compounds 2, 1 and 3 (each within the scatter of the next).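

In this assay, among these compounds, this change gives a 4.5-fold lower number from compound 3 to compound 4 (0.65 log units; beyond the scatter), the first step here that lies beyond the scatter, while the only earlier step (a 1.4-fold lower number from compound 1 to compound 2 (0.16 log units; within the scatter)), at the far end of the amide chain, stayed within it. The substituent on this aromatic carbon, ortho to a large group and meta to a trifluoromethyl group, can therefore shift the number measurably. The swap alters several things at once, since 1-((2-methoxyethyl)amino)-3-methylbutyl brings an oxygen and a second hydrogen-bond acceptor, has fewer carbons than 2-methyl-1-((2-methylbutyl)amino)butyl and arranges its chains differently, and no data at hand explain the size of this step.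

The compounds shown leave open whether the oxygen itself matters, which a plain butyl chain on the nitrogen in place of the 2-methoxyethyl chain would test, and whether a hydroxyl or a carboxylic acid at the end of that chain would lower the number further. They also leave open how an unsubstituted amine at this position compares when the far end of the amide chain stays the same as in compound 4.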